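The compounds below may be only part of what the source reports. "The series", "measured", "known", "first", "only" and "open" are said of these compounds alone.

Measured in a functional assay on A549 cells (Homo sapiens) for antiproliferative activity, read by MTT assay, with a stated time of 24 h; a higher number here means a weaker inhibitor, a lower number a stronger inhibitor:
- Compound 1 `O=C(NNc1ccccc1F)c1ccc(NS(=O)(=O)c2cnc(O)nc2O)cc1`: 11700 nM
- Compound 2 `O=C(NNc1ccc(F)cc1)c1ccc(NS(=O)(=O)c2cnc(O)nc2O)cc1`: > 20000 nM
- Compound 3 `O=C(NNC(=O)c1ccccc1F)c1ccc(NS(=O)(=O)c2cnc(O)nc2O)cc1`: 7610 nM

The entry for compound 2 is a limit of the assay, not a number. Compound 3 has the lowest of the two actual numbers, but the gap to compound 1 is small: a 1.5-fold lower number from compound 1 to compound 3 (0.19 log units; within the scatter). Compared with the limit, the picture is clearer: an at least 2.6-fold lower number from compound 2 to compound 3 (0.41 log units; beyond the scatter).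

Compound 4 `O=C(NNC(=O)c1ccc(NS(=O)(=O)c2cnc(O)nc2O)cc1)c1ccc(F)cc1` differs from compound 3 as follows: 4-fluorophenyl in place of 2-fluorophenyl on a carbonyl carbon. In words, it has 4-fluorophenyl in place of 2-fluorophenyl on a carbonyl carbon. The closest measured precedent is the same swap of fluorophenyl groups on an amine nitrogen: an at least 1.7-fold higher number from compound 1 to compound 2 (0.23 log units; that floor lies within the scatter). That step is only a floor and sits within the scatter, so it is a weak hint, though it does point toward weaker inhibition. A small rise in this assay is therefore expected, and the expected change is a 1.6-fold higher number from compound 3 to compound 4 (0.20 log units; within the scatter). The estimated value for compound 4 is 12000 nM, with an expected range of 6000 nM to 20000 nM.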

Compound 4, half-maximal inhibitory concentration: > 20000 nM
Compound 4: no number, only a limit (the forecaster's own chance of this, stated with the estimate: 25%); at least 1.6-fold (0.22 log units) between middle value and limit.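

Compound 4 carries a limit of the assay, not a number. Even so, on a carbonyl carbon the change from 2-fluorophenyl to 4-fluorophenyl gives the first readable effect of this swap in this assay: an at least 2.6-fold higher number from compound 3 to compound 4 (0.41 log units; beyond the scatter), while on an amine nitrogen the swap gave only a floor within the scatter, and both steps point toward weaker inhibition. The comparison with the amine-linked compound says less, since its floor also lies within the scatter: an at least 1.7-fold higher number from compound 1 to compound 4 (0.23 log units; that floor lies within the scatter).

The step from compound 2 to compound 4 cannot be read, because neither compound has an actual number: the limit of > 20000 nM in this assay, at which 2 of the 4 values shown sit. On these data alone, it remains open whether a plain phenyl or a chlorophenyl group on the same carbonyl carbon would stay close to compound 3 or rise to the limit.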